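The source may hold more compounds than are shown below. What is called first, only, known or untested is meant among the compounds shown, and "the series" means these compounds.

Three compounds that share the core of compound 1 `COc1cc2c(Nc3nc4ccc(C(=O)Nc5c(C)cccc5Cl)cc4s3)ncnc2cc1OCCCN1CCCCC1C` have been measured in a functional assay on HCT-116 cells (Homo sapiens) for cytotoxicity, read by WST assay, with a stated time of 72 h; a higher number here means a weaker inhibitor, a lower number a stronger inhibitor. In this assay compound 1 gives 7200 nM. Compound 2 `COc1cc2c(Nc3nc4ccc(C(=O)Nc5c(C)cccc5C)cc4s3)ncnc2cc1OCCCN1CCCCC1C` gives > 100000 nM, which is a limit of the assay rather than a number (the limit of > 100000 nM in this assay, at which 1 of the 3 values shown sits). Compound 3 `COc1cc2c(Nc3nc4ccc(C(=O)Nc5c(C)cc(C)cc5C)cc4s3)ncnc2cc1OCCCN1CCCCC1C` gives 5600 nM in this assay. Every step between these three changes the group on the amide-type nitrogen: an at least 13-fold higher number from compound 1 to compound 2 (1.14 log units; beyond the scatter); an at least 17-fold lower number from compound 2 to compound 3 (1.25 log units; beyond the scatter); and a 1.3-fold lower number from compound 1 to compound 3 (0.11 log units; within the scatter). Compound 3 therefore stands together with compound 1, the two within the scatter of each other, while compound 2 sits at the limit.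

Compound 4 `CCN(CC)CCCOc1cc2ncnc(Nc3nc4ccc(C(=O)Nc5c(C)cc(C)cc5C)cc4s3)c2cc1OC` departs from compound 3 at the other end of the molecule: diethylamino in place of 2-methylpiperidin-1-yl on a saturated chain carbon, three bonds along the chain from an oxygen on an aromatic ring. Among the compounds with values here, none of the measured steps touches this chain end; all of them concern the amide substituent, so they give no direct guide to the change. Within the data shown here, with no measured step bearing on it, the expectation for this assay is a step of no size beyond the scatter, no change at the digits printed from compound 3 to compound 4 (within the scatter). Compound 4 is thus estimated to give 5600 nM in this assay, within a range from 2200 nM to 14000 nM.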

Compound 4, half-maximal inhibitory concentration: 7500 nM
For compound 4 the middle estimate is 1.3-fold (0.13 log units) below the measured one; measured number inside the range.
By their numbers in this assay, from the lowest: compounds 3, 1 and 4 (each within the scatter of the next). At a limit, above all of these: compound 2.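

The amine at the end of the chain now has a measured step of its own: in this assay, diethylamino in place of 2-methylpiperidin-1-yl gives a 1.3-fold higher number from compound 3 to compound 4 (0.13 log units; within the scatter). At this place, on a saturated chain carbon, three bonds along the chain from an oxygen on an aromatic ring, the ring of the leaving group and its extra heavy atoms can therefore go without a change that stands out from the scatter, whereas a single change on the amide side gave an at least 17-fold lower number from compound 2 to compound 3 (1.25 log units; beyond the scatter). Nothing in the available data explains why these two amines read alike.

As far as these compounds go, it remains open whether this tolerance extends to other ends for the chain, such as a morpholine, a primary amine or a carboxylic acid, or to a shorter chain carrying the same diethylamino group. From the compounds shown here alone, it is also open whether diethylamino would read the same with the 2-chloro-6-methylphenyl group of compound 1 on the amide in place of the 2,4,6-trimethylphenyl group of compound 3.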